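Ethyl to Isopropyl on a Piperazine Urea Dithiocarbamate

The compounds below may be only part of what the source reports. "The series", "measured", "known", "first", "only" and "open" are said of these compounds alone.

Compound 1, `CC(C)NC(=O)N1CCN(C(=S)SCc2cn(Cc3ccc(Cl)cc3)nn2)CC1`: 25600 nM
Compound 2, `CCNC(=O)N1CCN(C(=S)SCc2cn(Cc3ccc(C)cc3)nn2)CC1`: > 128000 nM

Of the compounds shown here, two have been tested in a functional assay on EC9706 cells (Homo sapiens) for cytotoxicity, read by MTT assay, with a stated time of 72 h; a higher number here means a weaker inhibitor, a lower number a stronger inhibitor. Compound 1 gives 25600 nM. For compound 2 the assay reports only a limit, > 128000 nM, so compound 2 stands at the limit of > 128000 nM in this assay, at which 1 of the 2 values shown sits, and has no measured number of its own.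

Compound 3, `Cc1ccc(Cn2cc(CSC(=S)N3CCN(C(=O)NC(C)C)CC3)nn2)cc1`, is not yet measured. It differs from compound 2 by methyl in place of hydrogen on a saturated chain carbon bound to an amide-type nitrogen and a saturated chain carbon. Among the compounds with values here, no measured pair differs in this one place, so the size of this step cannot be read from the measured data. Compound 1 also carries the isopropyl group, though with a different group on its benzyl ring, and its measured number stands in the weak range. Compound 3 is therefore expected to remain a weak inhibitor, with a real chance that only a limit is reported again. The estimate for compound 3 is 80000 nM, within 25000 nM to 250000 nM. This estimate means a step of an at least 1.6-fold lower number from compound 2 to compound 3 (0.20 log units; that floor lies within the scatter) is expected.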

Compound 3, half-maximal inhibitory concentration: > 128000 nM
Compound 3 was reported as a limit; the forecaster's own chance of this, stated with the estimate: 45%; at least 1.6-fold (0.20 log units) between middle value and limit.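

In this assay, compound 3 is reported only as a limit, > 128000 nM, and this is no measured number. Compound 2 and compound 3 both rest on limits, so the step from ethyl to isopropyl cannot be read, and the isopropyl group alone shows no measurable gain here: the limit of > 128000 nM in this assay, at which 2 of the 3 values shown sit. With the isopropyl group held fixed, methyl in place of chloro on an aromatic carbon gives an at least 5.0-fold higher number from compound 1 to compound 3 (0.69 log units; beyond the scatter), so the one measured number among these compounds belongs to the chloro compound.

The compounds shown leave open whether ethyl to isopropyl changes anything once chloro stands on that aromatic carbon. They also leave open how a longer chain such as butyl in place of isopropyl, or a methoxy group in place of chloro, would read in this assay.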